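Methyl for hydroxy on the aryl ether of a macrolide

The compounds below may be only part of what the source reports. "The series", "measured", "known", "first", "only" and "open" are said of these compounds alone.

Three macrolides sharing one core have been measured in a functional assay on cells for inhibition, with Murine T-cell line (Mus musculus) as the target; a higher number here means a weaker inhibitor, a lower number a stronger inhibitor. Compound 1 `CC[C@@H]1/C=C(\C)C[C@H](C)C[C@H](OC)[C@H]2O[C@@](O)(C(=O)C(=O)N3CCCC[C@H]3C(=O)O[C@H](/C(C)=C/[C@@H]3CC[C@@H](Oc4cccc(O)c4)[C@H](OC)C3)[C@H](C)[C@@H](O)CC1=O)[C@H](C)C[C@@H]2OC` gives 1.7 nM. Compound 2 `CC[C@@H]1/C=C(\C)C[C@H](C)C[C@H](OC)[C@H]2O[C@@](O)(C(=O)C(=O)N3CCCC[C@H]3C(=O)O[C@H](/C(C)=C/[C@@H]3CC[C@@H](Oc4ccc(O)cc4)[C@H](O)C3)[C@H](C)[C@@H](O)CC1=O)[C@H](C)C[C@@H]2OC` gives 1.6 nM, and compound 3 `CC[C@@H]1/C=C(\C)C[C@H](C)C[C@H](OC)[C@H]2O[C@@](O)(C(=O)C(=O)N3CCCC[C@H]3C(=O)O[C@H](/C(C)=C/[C@@H]3CC[C@@H](O)[C@H](Oc4ccccc4)C3)[C@H](C)[C@@H](O)CC1=O)[C@H](C)C[C@@H]2OC` gives 3.2 nM. Compound 1 holds the second highest of the three numbers, but its gaps to compound 2 and to compound 3 both stay within the scatter, so the three cannot be ranked.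

Compound 4 `CC[C@@H]1/C=C(\C)C[C@H](C)C[C@H](OC)[C@H]2O[C@@](O)(C(=O)C(=O)N3CCCC[C@H]3C(=O)O[C@H](/C(C)=C/[C@@H]3CC[C@@H](Oc4cccc(C)c4)[C@H](OC)C3)[C@H](C)[C@@H](O)CC1=O)[C@H](C)C[C@@H]2OC` has not yet been measured. It differs from compound 1 by methyl in place of hydroxy on an aromatic carbon, placed on a six-membered aromatic ring of carbon only, meta to a large group. Within the data shown here, no measured pair shows exactly this change. The step of a 1.3-fold higher number from compound 1 to compound 4 (0.11 log units; within the scatter) is expected to be small, in either direction, not beyond the scatter. Compound 4 is thus expected to give about 2.2 nM in this assay, within 0.8 nM to 6 nM.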

Compound 4, half-maximal inhibitory concentration: 5.4 nM
For compound 4 the middle estimate is 2.5-fold (0.39 log units) below the measured one; the measured number falls inside the stated range.
By their numbers in this assay, from the lowest: compounds 2, 1, 3 and 4 (each within the scatter of the next, the first and the last beyond it).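

Going from 3-hydroxyphenoxy to 3-methylphenoxy gives a 3.2-fold higher number from compound 1 to compound 4 (0.50 log units; beyond the scatter), a modest step and the first single-place comparison in this set. The hydroxy on this aromatic carbon is therefore not freely interchangeable with methyl in this assay, although the number stays in the low nanomolar range. No measurement here bears on what lies behind the step.

The compounds shown leave open whether the step reflects losing hydroxy or gaining methyl. An amine, a fluorine or plain hydrogen on the same carbon could separate the two.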